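Swapping the Amine Substituent on a Shared Core

The source may hold more compounds than are shown below. What is called first, only, known or untested is meant among the compounds shown, and "the series" means these compounds.

Compound 1 `CCCN(CCC(F)(F)F)Cc1c(C(F)(F)F)nc2n(-c3c(C)cc(C)cc3C)c(Cl)cn12`: 12 nM
Compound 2 `CCCCN(C)Cc1c(C(F)(F)F)nc2n(-c3c(C)cc(C)cc3C)c(Cl)cn12`: 310 nM
Compound 3 `CCN(CCC1CC1)Cc1c(C(F)(F)F)nc2n(-c3c(C)cc(C)cc3C)c(Cl)cn12`: 13 nM

These three compounds share one core and differ only in the amine on a saturated chain carbon bound to an aromatic carbon. In an assay on cells for displacement of a labelled ligand from corticotropin-releasing factor receptor 1 (Homo sapiens), with a stated time of 100 min (on this read-out lower numbers stand for stronger inhibition and higher numbers for weaker inhibition), compound 3 gives 13 nM; against compound 1 the step was a 1.1-fold higher number from compound 1 to compound 3 (0.03 log units; within the scatter), and against compound 2 it was a 24-fold lower number from compound 2 to compound 3 (1.38 log units; beyond the scatter). Compound 4 `CCCN(Cc1ccccc1)Cc1c(C(F)(F)F)nc2n(-c3c(C)cc(C)cc3C)c(Cl)cn12` carries the change (benzyl(propyl)amino in place of (2-cyclopropylethyl)(ethyl)amino on a saturated chain carbon bound to an aromatic carbon). Among the measured compounds shown here, no measured step involves benzyl(propyl)amino, so the expectation rests on the two steps above: compound 1 and compound 3 sit close together, while only compound 2 stands far weaker. Compound 4 keeps a propyl and a second larger group, so a step near a 1.5-fold higher number from compound 3 to compound 4 (0.19 log units; within the scatter) is expected, within the scatter. Compound 4 is estimated at 20 nM, with a range of 5 nM to 80 nM.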

Compound 4, inhibition constant: 170 nM
Compound 4: middle estimate off by 8.5-fold (0.93 log units), on the low side, and the stated range ends below it.
By their numbers in this assay, from the lowest: compounds 1 and 3 (each within the scatter of the next); then compounds 4 and 2 (each within the scatter of the next).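

Keeping a propyl on the amine nitrogen does not preserve the low numbers: phenyl in place of 2,2,2-trifluoroethyl gives a 14-fold higher number from compound 1 to compound 4 (1.15 log units; beyond the scatter) and benzyl(propyl)amino in place of (2-cyclopropylethyl)(ethyl)amino gives a 13-fold higher number from compound 3 to compound 4 (1.12 log units; beyond the scatter) as well. Against butyl(methyl)amino the step is a 1.8-fold lower number from compound 2 to compound 4 (0.26 log units; within the scatter) and so the higher numbers at this position are not confined to compound 2. Going by these compounds, whether a 2-phenylethyl or cyclohexylmethyl group in place of benzyl would restore the lower numbers stays open. Nothing available here accounts for the loss seen with benzyl.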